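The compounds below may be only part of what the source reports. "The series", "measured", "known", "first", "only" and "open" are said of these compounds alone.

Working notes on the series. In a functional assay on BT-549 cells (Homo sapiens) for cytotoxicity, read by sulforhodamine B assay, with a stated time of 48 h (a lower number here means a stronger inhibitor of growth, a higher number a weaker inhibitor of growth), compound 1 `ClCc1ccc(Cn2cnc3c(Cl)ncnc32)cc1` gives 5620 nM, compound 2 `ClCc1ccccc1Cn1cnc2ncnc(Cl)c21` gives 2450 nM, and compound 3 `ClCc1ccc(Cn2cnc3c(Cl)nc(Cl)nc32)cc1` gives 15900 nM. Compound 2 shares its atoms with compound 1 joined differently; the difference between the two cores is not broken down here. The change chloro in place of hydrogen on an aromatic carbon gave a 2.8-fold higher number from compound 1 to compound 3 (0.45 log units; beyond the scatter). Compound 4 `ClCc1ccccc1Cn1cnc2nc(Cl)nc(Cl)c21` is not yet measured in this assay and arises from compound 2 by chloro in place of hydrogen on an aromatic carbon, the same change at the same kind of place as that from compound 1 to compound 3. Resting on the single earlier step of a 2.8-fold higher number from compound 1 to compound 3 (0.45 log units; beyond the scatter), compound 4 is expected to give a higher number than compound 2, and the expected step is a 2.8-fold higher number from compound 2 to compound 4 (0.45 log units; beyond the scatter). Compound 4 is estimated at 6900 nM, likely between 3500 nM and 14000 nM.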

Compound 4, concentration for 50% growth inhibition: 1340 nM
The estimate for compound 4 lay 5.1-fold (0.71 log units) above the measured number; measured number below the stated range.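

In this assay the change chloro in place of hydrogen on an aromatic carbon stays within the scatter on the newly read core (a 1.8-fold lower number from compound 2 to compound 4 (0.26 log units; within the scatter)). The step therefore does not carry from one core to the other in this series: the same change on two cores in this assay, a 2.8-fold higher number (0.45 log units; beyond the scatter) from compound 1 to compound 3 and a 1.8-fold lower number (0.26 log units; within the scatter) from compound 2 to compound 4, 5.2-fold (0.71 log units) apart, beyond the scatter of two such steps. This rests on a single pair per core, so it does not show why the two cores part, nor how the change would run on a further core. Open, as far as these compounds go, is whether an amine or a methoxy group, placed between the two ring nitrogen atoms instead of chloro, would give steps that agree on the two cores.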